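Swapping the Aryl Group on the Shared Core

A few compounds are considered here, and "the series" means these few. Any claim that something is new, unique, unknown or untested is made for them only; others in the source may bear on it.

Of the compounds shown here, two that share one core have been measured. Compound 1 `COc1cc(N2C(N)=C(C#N)C(c3ccc([N+](=O)[O-])cc3)C3=C2CC(C)(C)CC3=O)cc(OC)c1OC` gives 70% in a functional assay on Ehrlich cells (Mus musculus) for cytotoxicity, tested at 50 ug/mL; on this read-out higher numbers stand for a stronger effect at the one concentration tested and lower numbers for a weaker effect. Among the compounds with values here, compound 2 `COc1cc(N2C(N)=C(C#N)C(c3ccc(OC)c4ccccc34)C3=C2CC(C)(C)CC3=O)cc(OC)c1OC` gives 40% in this assay, which places compound 2 lowest of the two numbers, with compound 1 the only neighbour and standing higher by a step beyond the scatter. Within the data shown here, the one measured step, a number 30 percentage points lower from compound 1 to compound 2 (beyond the scatter), shows that exchanging the group on this saturated ring carbon can move the read-out by a modest but real amount. Compound 3 `COc1cc(N2C(N)=C(C#N)C(c3ccc(C)cc3)C3=C2CC(C)(C)CC3=O)cc(OC)c1OC` is not yet measured; it differs from compound 2 by 4-methylphenyl in place of 4-methoxynaphthalen-1-yl on a saturated ring carbon. Among the measured compounds shown here, no measured step covers exactly this exchange, so the expectation is uncertain. A return to a single aromatic ring is expected to lift the number part of the way back, a step of a number 15 percentage points higher from compound 2 to compound 3 (beyond the scatter). Compound 3 is therefore estimated at 55%, within 35% to 75%.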

Compound 3, a percentage reported as activity, at one concentration (the size of the read-out at that concentration, not a potency): 60%
Compound 3: middle estimate off by 5 percentage points, on the low side; the range from low to high includes it.
By their numbers in this assay, from the lowest: compound 2; then compounds 3 and 1 (each within the scatter of the next).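

In this assay the step of a number 20 percentage points higher from compound 2 to compound 3 (beyond the scatter) shows that a second single-ring aryl group also stands clear of 4-methoxynaphthalen-1-yl, so the earlier gap does not rest on 4-nitrophenyl alone. The comparison a number 10 percentage points lower from compound 1 to compound 3 (within the scatter) leaves methyl and nitro on that aromatic carbon indistinguishable in this read-out, and among these three compounds the only separation beyond the scatter is between compound 2 and the two compounds with a single-ring aryl group. No outside evidence bears on why the numbers fall this way.

The compounds shown do not tell whether the second aromatic ring or the methoxy group of 4-methoxynaphthalen-1-yl goes with the smaller number. On these data alone, how an amine or a carboxylic acid on the same aromatic carbon would read also stays open.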